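The source may report more compounds than this note shows. Statements on the series, on what has been measured and on what is new or still open speak of the compounds shown alone.

Three compounds have been measured in a functional assay on DU-145 cells (Homo sapiens) for inhibition, read by trypan blue exclusion, with a stated time of 96 h; on this read-out lower numbers stand for stronger inhibition of growth and higher numbers for weaker inhibition of growth:

Compound 1 `Cc1ccc(CS(=O)(=O)/C(=C/c2cccc(Cl)c2Cl)C(=O)c2ccc(Cl)cc2)cc1` gives 1000 nM.
Compound 2 `COc1ccc(/C=C(\C(=O)c2ccc(Cl)cc2)S(=O)(=O)c2ccc(Br)cc2)cc1` gives 10000 nM.
Compound 3 `CSc1ccc(/C=C(\C(=O)c2ccc(Br)cc2)S(=O)(=O)Cc2ccc(C)cc2)cc1` gives 10000 nM.

Compound 1 stands at the lowest number of the three, so it inhibits growth most strongly; compound 2 and compound 3 both sit at higher numbers, and each gap lies beyond the usual scatter. No pair of these compounds differs in only one place, so no single step can be read from them.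

Compound 4 `Cc1ccc(CS(=O)(=O)/C(=C/c2ccccc2Br)C(=O)c2ccc(Cl)cc2)cc1` differs from compound 1 in one place: 2-bromophenyl in place of 2,3-dichlorophenyl on a double-bonded chain carbon bound to a double-bonded chain carbon. Among the compounds with values here, since no comparable step is available among the measured compounds, the change is expected to give a small step in this assay, toward weaker inhibition of growth or none beyond the scatter. Compound 4 is therefore estimated at 1500 nM, with a range from 500 nM to 6000 nM. This estimate means an expected step of a 1.5-fold higher number from compound 1 to compound 4 (0.18 log units; within the scatter).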

Compound 4, concentration for 50% growth inhibition: 25000 nM
The estimate for compound 4 lay 17-fold (1.22 log units) below the measured number; the measured number lies above the stated range.
By their numbers in this assay, from the lowest: compound 1; then compounds 2 and 3 (each within the scatter of the next); then compound 4.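

The group on this double-bonded chain carbon matters strongly: in this assay, 2-bromophenyl in place of 2,3-dichlorophenyl gives a 25-fold higher number from compound 1 to compound 4 (1.40 log units; beyond the scatter), a large loss of growth inhibition from a single change. The earlier compounds shown here differed from one another in more than one place, so they could not isolate the effect of any one group. No measured property bears on the reason for this step.

The bromine and the removal of the chlorines arrive together, so their separate contributions remain unresolved. From the compounds shown here alone, how an amine or a carboxylic acid on this ring would fare also remains open.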